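This account rests on a few compounds, and the source may have more. Where it says the series, first, only, none or still open, it means among the compounds named here.

Three compounds have been measured so far in a functional assay on MDA-MB-231 cells (Homo sapiens) for antiproliferative activity, read by MTT assay (a lower number here means a stronger inhibitor, a higher number a weaker inhibitor), as follows
compound 1 `CC/C=C\C/C=C\C/C=C\CCCCCCCc1cc(=O)c2c(O)cc(O)cc2o1` at 6790 nM
compound 2 `CC/C=C\C/C=C\C/C=C\CCCCCCCc1cc(=O)c2c(O)cc(OCOC)cc2o1` at 6790 nM
compound 3 `CC/C=C\C/C=C\C/C=C\CCCCCCCc1cc(=O)c2c(O)c(C)c(O)cc2o1` at 6790 nM

Compound 1 stands at 6790 nM in this assay and is level with compound 2 and compound 3 at the digits reported. The next compound, compound 4 `CCCCC/C=C\C/C=C\CCCCCCCc1cc(=O)c2c(O)cc(O)cc2o1`, keeps the core of compound 1 and alters only the long chain, where butyl takes the place of but-1-en-1-yl on a saturated chain carbon bound to a double-bonded chain carbon (butyl in place of but-1-en-1-yl on a saturated chain carbon bound to a double-bonded chain carbon). Two measured steps start from compound 1. One, no change at the digits printed from compound 1 to compound 2 (within the scatter), puts methoxymethyl in place of hydrogen on an oxygen on an aromatic ring. The other, no change at the digits printed from compound 1 to compound 3 (within the scatter), puts methyl in place of hydrogen on an aromatic carbon. Within the data shown here, both changes lie on the shared core, so they bear on the chain change only indirectly, and no measured compound varies the chain. With neither step moving the value, no shift beyond the scatter is expected in this assay, though this rests on thin evidence. The expected step is a 1.0-fold higher number from compound 1 to compound 4 (0.00 log units; within the scatter) in size. For compound 4 the estimate is 6800 nM, with an expected range from 3400 nM to 13500 nM for the coming measurement.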

Compound 4, half-maximal inhibitory concentration: 6790 nM
Compound 4: the middle estimate sits 1.0-fold (0.00 log units) above what was measured; measured number inside the range.
By their numbers in this assay, from the lowest: compounds 1, 2, 3 and 4 (each within the scatter of the next).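

In this assay, the long chain now has a measured step of its own: butyl in place of but-1-en-1-yl on a saturated chain carbon bound to a double-bonded chain carbon gives no change at the digits printed from compound 1 to compound 4 (within the scatter). Among these compounds, the earlier steps touched only the shared core, so this is the first reading from the chain, and it shows that at this place the double bond carried by but-1-en-1-yl can give way to the saturated butyl, with the same count of heavy atoms, without any shift beyond the scatter. Nothing on hand speaks to what lies behind this flat result.

On these data alone, whether a shorter chain, a longer chain, or a chain ending in a carboxylic acid or an amine would move the number remains open. Also open is whether the core changes and the chain change would stay level when combined in one compound, since every step shown lies within the scatter and none offers a shift to compare against.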